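Swapping Acetyl for Trifluoromethyl on a Shared Core

The source may report more compounds than this note shows. Statements on the series, on what has been measured and on what is new or still open speak of the compounds shown alone.

Compound 1, `COC(=O)c1sc2cc(-c3ccc(C#N)cc3)cnc2c1N`: > 75000 nM
Compound 2, `COC(=O)c1sc2cc(-c3ccc(C(C)=O)cc3)cnc2c1N`: > 150000 nM

Of the compounds shown here, two have been measured in a functional assay on MCF7 cells (Homo sapiens) for inhibition, read by sulforhodamine B assay, with a stated time of 48 h; a lower number here means a stronger inhibitor of growth, a higher number a weaker inhibitor of growth. In this assay compound 1 gives > 75000 nM, which is a limit of the assay and not a number. In this assay compound 2 gives > 150000 nM, again a limit rather than a number. Compound 2 therefore stands at the edge of what the assay can report, and so does compound 1. Among the measured compounds shown here, the single measured step, a step that the two limits leave unreadable from compound 1 to compound 2, cannot be sized because the limit of > 75000 nM in this assay, at which 1 of the 2 values shown sits, and the limit of > 150000 nM in this assay, at which 1 of the 2 values shown sits, are both limits.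

Compound 3, `COC(=O)c1sc2cc(-c3ccc(C(F)(F)F)cc3)cnc2c1N`, differs from compound 2 in one place: trifluoromethyl in place of acetyl on an aromatic carbon. For the measured compounds named here, the one measured step bears on this change only in that neither of its ends gave a number, so no direction beyond the scatter can be read from it. Compound 3 is therefore expected to stay weak in this assay, with an estimated value of 150000 nM and a range from 50000 nM to 450000 nM. The step this estimate implies, a number no higher from compound 2 to compound 3 (the limit leaves the size open), is expected to be none beyond the scatter.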

Compound 3, concentration for 50% growth inhibition: > 150000 nM
Compound 3 was reported as a limit; the forecaster's own chance of this, stated with the estimate: 85%; the middle value lies on the limit itself.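

Compound 3 also gives a limit of the assay and not a number, so neither the step from compound 2 to compound 3 nor the step from compound 1 to compound 3 can be read: the limit of > 150000 nM in this assay, at which 2 of the 3 values shown sit. The compounds shown leave open how strongly each inhibits growth in this assay, and whether swapping these groups changes that at all.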